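Working notes on cytotoxicity readings in one series

The source may report more compounds than this note shows. Statements on the series, on what has been measured and on what is new or still open speak of the compounds shown alone.

Measured so far:
Compound 1: `COc1ccc(F)cc1CNCCCNc1ccnc2cc(C3CCCCC3)ccc12`, 2290 nM
Compound 2: `CCC(CC)c1ccc2c(NCCCNCc3ccco3)ccnc2c1`, 6760 nM

In an ADME assay on HepG2 cells (Homo sapiens) for cytotoxicity, read by luminescence, CellTiter-Glo and ATP content, with a stated time of 72 h (a lower number here means that less compound is needed, a higher number that more compound is needed for the effect), compound 1 stands lowest of the two numbers; compound 2 sits beyond the scatter above it. Compound 3 is `COc1ccc(F)cc1CNCCCNc1ccnc2cc(Oc3ccc(Cl)cc3)ccc12`. It differs from compound 1 in one place: 4-chlorophenoxy in place of cyclohexyl on an aromatic carbon. Among the measured compounds shown here, no measured pair shows such a change, so the direction cannot be read from the data; the expected step in this assay is small, likely no further than the scatter, as a 1.1-fold lower number from compound 1 to compound 3 (0.06 log units; within the scatter). For compound 3 the estimated value in this assay is 2000 nM, with a range from 800 nM to 5000 nM.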

Compound 3, half-maximal effective concentration: 4500 nM
For compound 3 the middle estimate is 2.3-fold (0.35 log units) below the measured one, and the stated range covers the measured number.
By their numbers in this assay, from the lowest: compounds 1, 3 and 2 (each within the scatter of the next, the first and the last beyond it).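

In this assay, 4-chlorophenoxy in place of cyclohexyl on this aromatic carbon gives a 2.0-fold higher number from compound 1 to compound 3 (0.29 log units; within the scatter) and so shows that, at this position, the two groups are not separated beyond the scatter. Among the compounds shown here, this is the first comparison that differs in one place, and it rests on a single pair. No measured evidence bears on the reason for this result. Still open, going by these compounds, is how an amine or a carboxylic acid would read at this position. Also open, on these data alone, is whether the same change gives a similar step with the side chain of compound 2.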